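Two limits and one untested replacement group

The source may hold more compounds than are shown below. What is called first, only, known or untested is meant among the compounds shown, and "the series" means these compounds.

Compound 1 `CC(=O)OC[C@H]1O[C@@H](n2cc(Cn3cc(C(C)=O)c4ccccc43)nn2)[C@H](OC(C)=O)[C@@H](OC(C)=O)[C@@H]1OC(C)=O` and compound 2 `CC(=O)OC[C@H]1O[C@@H](n2cc(Cn3cc(/C=C/C(=O)c4cccnc4)c4ccccc43)nn2)[C@H](OC(C)=O)[C@@H](OC(C)=O)[C@@H]1OC(C)=O` share one core and differ in a single group. In a functional assay on HeLa cells (Homo sapiens) for cytotoxicity, read by sulforhodamine B assay, with a stated time of 48 h (a lower number here means a stronger inhibitor, a higher number a weaker inhibitor), compound 1 gives > 200000 nM as its result, which is a limit and not a number. In this assay compound 2 gives > 200000 nM as its result, again a limit and not a number. Compound 2 therefore has no numerical standing, and both compounds sit at the limit of > 200000 nM in this assay, at which 2 of the 2 values shown sit, without further spread.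

Going by the values given here, the only measured step, a step that the two limits leave unreadable from compound 1 to compound 2, put 2-((pyridin-3-yl)carbonyl)ethenyl in place of acetyl, and it offers no size to carry forward. Compound 3 `CC(=O)OC[C@H]1O[C@@H](n2cc(Cn3cc(/C=C4/C(=O)Nc5ccc(F)cc54)c4ccccc43)nn2)[C@H](OC(C)=O)[C@@H](OC(C)=O)[C@@H]1OC(C)=O` differs from compound 2 in that group, as a group of 12 heavy atoms (9 carbon, 1 nitrogen, 1 oxygen, 1 fluorine; one five-membered non-aromatic ring with 1 hetero atom, one six-membered aromatic ring of carbon only) in place of a group of 10 heavy atoms (8 carbon, 1 nitrogen, 1 oxygen; one six-membered aromatic ring with 1 hetero atom), on an aromatic carbon shows. With no readable step behind it, only a small move towards stronger inhibition in this assay is expected, and compound 3 may well remain at the limit. The expected change is an at least 1.6-fold lower number from compound 2 to compound 3 (0.22 log units; that floor lies within the scatter) in this estimate. For compound 3 the estimated value is 120000 nM with an expected range from 20000 nM to 200000 nM in the same assay.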

Compound 3, half-maximal inhibitory concentration: > 200000 nM
Compound 3 was reported as a limit; the forecaster's own chance of this, stated with the estimate: 60%; middle value at least 1.6-fold (0.22 log units) from the limit.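

In this assay compound 3 gives > 200000 nM, a limit and not a number. No step between compound 1, compound 2 and compound 3 can be read, and all three stand at one limit: the limit of > 200000 nM in this assay, at which 3 of the 3 values shown sit.

The compounds shown leave open which group on this aromatic carbon, if any, would give a numerical value in this assay.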